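Adding Chloro to Compound 2 at the Assay Limit

The compounds below may be only part of what the source reports. "The series", "measured", "known", "first", "only" and "open" are said of these compounds alone.

Of the compounds shown here, three have been measured so far: compound 1 `CN1C(=O)C(O)(Cc2nnn[nH]2)c2ccccc21`, compound 2 `CCN1C(=O)C(O)(Cc2nnn[nH]2)c2ccccc21` and compound 3 `O=C1N(Cc2ccc(Br)cc2)c2ccc(F)cc2C1(O)Cc1nnn[nH]1`. In a functional assay on BT-549 cells (Homo sapiens) for antiproliferative activity, read by MTT assay, with a stated time of 48 h (on this read-out lower numbers stand for stronger inhibition and higher numbers for weaker inhibition), compound 1 gives > 100000 nM, which is a limit and not a number. In this assay compound 2 gives > 100000 nM, which is also a limit. In this assay compound 3 gives > 100000 nM, again a limit. Compound 2 therefore stands with the other two at the limit of > 100000 nM in this assay, at which 3 of the 3 values shown sit, and no actual number is known for any of them.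

The next compound is compound 4 `CCN1C(=O)C(O)(Cc2nnn[nH]2)c2cc(Cl)ccc21`. It differs from compound 2 by chloro in place of hydrogen on an aromatic carbon, with chloro in place of hydrogen on an aromatic carbon. Within the data shown here, only one measured step bears on this change, and it bears weakly: a step that the two limits leave unreadable from compound 1 to compound 2. That step is a methyl in place of hydrogen on a saturated chain carbon, not a chloro on an aromatic carbon, and it has no readable size to carry over. No shift in either direction can be drawn from it, so no change beyond the scatter is expected in this assay. The expected step is a number no higher from compound 2 to compound 4 (the limit leaves the size open). Compound 4 is estimated at 100000 nM, with an expected range from 40000 nM to 200000 nM.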

Compound 4, half-maximal inhibitory concentration: 85400 nM
Compound 4: the middle estimate sits 1.2-fold (0.07 log units) above what was measured, within the range that was stated.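

Chloro in place of hydrogen on an aromatic carbon, meta to a fused ring and para to a fused ring, is the first change in this assay to bring a compound off the limit, and it gives an at least 1.1-fold lower number from compound 2 to compound 4 (0.06 log units; that floor lies within the scatter). Going by these compounds, compound 2 gives > 100000 nM, which is a limit and not a number, so the true size of this step stays open and its floor alone shows no shift beyond the scatter. What the chloro adds to the earlier picture is a first measured number for this series, as compound 4 stands apart from the other three compounds, which remain at: the limit of > 100000 nM in this assay, at which 3 of the 4 values shown sit.

The compounds shown leave open whether a bromo, a methoxy or an amine on this same aromatic carbon would give a number of similar size or a different one. They also leave open whether the chloro would give a readable number on the core of compound 1, or whether a longer chain in place of the ethyl of compound 4 would alter its value.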